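Working notes: nitro step from compound 2

The source may hold more compounds than are shown below. What is called first, only, known or untested is meant among the compounds shown, and "the series" means these compounds.

In a functional assay on SH-SY5Y cells (Homo sapiens) for cytotoxicity, read by MTT assay, with a stated time of 48 h (on this read-out higher numbers stand for weaker inhibition and lower numbers for stronger inhibition), compound 2 `COc1ccc(/C=C/C(=O)/C=C/c2nc3ccccc3n2C)cc1O` gives 4800 nM and stands level with compound 1 `COc1cc(/C=C/C(=O)/C=C/c2nc3cc(O)ccc3n2C)ccc1O` at 4800 nM as the lowest number of the three measured. Compound 3 `COc1ccc(/C=C/C(=O)/C=C/c2nc3c(C)cccc3n2C)cc1O` gives a higher number (19100 nM).

The change under review leads to compound 4 `COc1ccc(/C=C/C(=O)/C=C/c2nc3cc([N+](=O)[O-])ccc3n2C)cc1O` with nitro in place of hydrogen on an aromatic carbon of the shared core. Within the data shown here, no measured compound carries nitro. Among the measured compounds shown here, the only measured step that bears on this one also replaces hydrogen on an aromatic carbon, but with methyl. That modest step, a 4.0-fold higher number from compound 2 to compound 3 (0.60 log units; beyond the scatter), lies beyond the scatter and involves a different group, so it offers only a loose precedent.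

The step expected in this assay is a 1.7-fold higher number from compound 2 to compound 4 (0.22 log units; within the scatter) toward a higher number, smaller than the methyl step and held with little certainty. For compound 4 the expected value is 8000 nM with an estimated range of 2500 nM to 25000 nM around it.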

Compound 4, half-maximal inhibitory concentration: 8100 nM
Compound 4: middle estimate off by 1.0-fold (0.01 log units), on the low side; measured number inside the range.
By their numbers in this assay, from the lowest: compounds 1, 2 and 4 (each within the scatter of the next); then compound 3.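

In this assay, nitro in place of hydrogen on an aromatic carbon of the shared core gives a step that stays within the scatter (a 1.7-fold higher number from compound 2 to compound 4 (0.23 log units; within the scatter)), so compound 4 shows that this position accepts a group of 3 heavy atoms with no change that can be told from repeat variation. The methyl replacement in compound 3 (a 4.0-fold higher number from compound 2 to compound 3 (0.60 log units; beyond the scatter)) lies beyond the scatter, so not every replacement of hydrogen on an aromatic carbon of compound 2 stays within it. No supporting measurement accounts for either step, and the group cannot be separated from its place on the core.

As far as these compounds go, whether an amine or a carboxylic acid at the nitro position would also stay within the scatter remains open. So does how nitro and methyl would compare on the same aromatic carbon.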